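Methoxy additions on the chalcone series

This account rests on a few compounds, and the source may have more. Where it says the series, first, only, none or still open, it means among the compounds named here.

Compound 1 `O=C(/C=C/c1ccc(O)c(O)c1)c1ccccc1Cl` gives 92 nM in an assay on RBL-1 cells for inhibition of Polyunsaturated fatty acid 5-lipoxygenase (Rattus norvegicus); on this read-out higher numbers stand for weaker inhibition and lower numbers for stronger inhibition. Among the compounds with values here, compound 2 `COc1ccccc1C(=O)/C=C/c1ccc(O)c(O)c1` gives 27 nM in this assay and stands second highest of the three numbers measured so far, between compound 3 and compound 1. Compound 3 `COc1ccc(C(=O)/C=C/c2ccc(O)c(O)c2)c(OC)c1` gives 10 nM. The step from compound 1 to compound 2 is a 3.4-fold lower number from compound 1 to compound 2 (0.53 log units; beyond the scatter), and the step from compound 2 to compound 3 is a 2.7-fold lower number from compound 2 to compound 3 (0.43 log units; beyond the scatter).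

Compound 4 `COc1ccc(OC)c(C(=O)/C=C/c2ccc(O)c(O)c2)c1` has not been measured. It differs from compound 2 by methoxy in place of hydrogen on an aromatic carbon. Within the data shown here, the one measured step that bears on it is a 2.7-fold lower number from compound 2 to compound 3 (0.43 log units; beyond the scatter), also a methoxy in place of hydrogen on the same ring, though at a different place. Among the measured compounds shown here, on that basis compound 4 is expected to show a modest lowering of the number, estimated as a 1.8-fold lower number from compound 2 to compound 4 (0.26 log units; within the scatter), with a wider range because the place of the new methoxy has no measured counterpart. Compound 4 is therefore estimated at 15 nM, within 6 nM to 40 nM.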

Compound 4, half-maximal inhibitory concentration: 7.8 nM
Compound 4: the middle estimate sits 1.9-fold (0.28 log units) above what was measured, and the stated range covers the measured number.
By their numbers in this assay, from the lowest: compounds 4 and 3 (each within the scatter of the next); then compound 2; then compound 1.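

A methoxy in place of hydrogen, para to the existing methoxy group and meta to a large group, gives a 3.5-fold lower number from compound 2 to compound 4 (0.54 log units; beyond the scatter) and shows that this place also tolerates the added group. Compound 3 at 10 nM and compound 4 at 7.8 nM lie within the scatter of each other in this assay, so these two places for a second methoxy on the ring cannot be told apart on this read-out. Nothing available explains the lowering at this place.

The compounds shown leave open whether the lowering is specific to methoxy or extends at this place to a longer chain such as ethoxy, or to an amine. They also leave open whether a methoxy here lowers the number when the existing methoxy group is replaced by chloro, as in compound 1.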